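A Hydroxyl in Place of Two Chlorines

This account rests on a few compounds, and the source may have more. Where it says the series, first, only, none or still open, it means among the compounds named here.

Within the data shown here, compound 2 `O=S(=O)(/C=C/c1ccc(Cl)c(Cl)c1)Cc1ccc(Nc2ncnc3ccccc23)cc1` holds the only number measured so far: in a functional assay on PC-3 cells (Homo sapiens) (a higher number here means a weaker inhibitor of growth, a lower number a stronger inhibitor of growth), compound 2 gives 35000 nM. Compound 1 `O=S(=O)(/C=C/c1ccccc1)Cc1ccc(Nc2ncnc3ccccc23)cc1` gives in this assay only a limit, > 100000 nM. Among the measured compounds shown here, the step of an at least 2.8-fold lower number from compound 1 to compound 2 (0.45 log units; beyond the scatter) is the single measured step that bears on compound 3 `O=S(=O)(/C=C/c1ccc(O)cc1)Cc1ccc(Nc2ncnc3ccccc23)cc1`, which differs from compound 2 by 4-hydroxyphenyl in place of 3,4-dichlorophenyl on a double-bonded chain carbon bound to a double-bonded chain carbon. That earlier step, bounded by the limit of > 100000 nM in this assay, at which 1 of the 2 values shown sits, added the two chlorines that compound 3 again lacks, so compound 3 is expected to return toward the weaker end. The estimate for compound 3 in this assay is 80000 nM (range 30000 nM to 200000 nM), an expected step of a 2.3-fold higher number from compound 2 to compound 3 (0.36 log units; beyond the scatter).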

Compound 3, concentration for 50% growth inhibition: 14000 nM
For compound 3 the middle estimate is 5.7-fold (0.76 log units) above the measured one, outside the stated range (below it).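

In this assay, the two chlorines are not what lowers the number at this place, since 4-hydroxyphenyl goes further than 3,4-dichlorophenyl, with a 2.5-fold lower number from compound 2 to compound 3 (0.40 log units; beyond the scatter). Against the plain phenyl, hydroxy in place of hydrogen on an aromatic carbon gives an at least 7.1-fold lower number from compound 1 to compound 3 (0.85 log units; beyond the scatter). That step is open at one end, resting on a limit and not a number: the limit of > 100000 nM in this assay, at which 1 of the 3 values shown sits.

Still open, going by these compounds, is whether the hydroxy itself is needed, or whether a methoxy or an amine in its place would give a similar number in this assay.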